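This account rests on a few compounds, and the source may have more. Where it says the series, first, only, none or still open, it means among the compounds named here.

Measured so far in an ADME assay on MRC5 cells (Homo sapiens) for inhibition, with a stated time of 72 h; on this read-out lower numbers stand for an effect already at smaller amounts and higher numbers for an effect only at larger amounts of compound:

compound 1, `COCCNC(=O)c1n[nH]cc1NC(=O)c1c(OC)cccc1OC`, gives > 50000 nM.
compound 2, `CO[C@H]1CC[C@H](NC(=O)c2n[nH]cc2NC(=O)c2ccc(N3CCN(C)CC3)cc2)CC1`, gives 20000 nM.

Compound 1 stands at a limit of this assay and not at a number: the limit of > 50000 nM in this assay, at which 1 of the 2 values shown sits. Within the data shown here, compound 2 is the only compound of the pair with a number in this assay. Among the measured compounds shown here, no step between the two measured compounds is available, as they differ in more than one place, so only their two values can be read side by side.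

Compound 3, `COc1cccc(OC)c1C(=O)Nc1c[nH]nc1C(=O)Nc1ccccc1`, differs from compound 1 by phenyl in place of 2-methoxyethyl on an amide-type nitrogen. For the measured compounds named here, no measured step covers this change, so nothing shows how this assay answers to it. The expectation is that the step of an at least 1.2-fold lower number from compound 1 to compound 3 (0.09 log units; that floor lies within the scatter) stays small, with a slight lean towards an effect at smaller amounts, since an aromatic ring enters where a short chain left; the change remains within or near the scatter of this assay. Compound 3 is therefore estimated at 40000 nM, with a range from 15000 nM to 100000 nM, and it may again be reported only as a limit.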

Compound 3, half-maximal effective concentration: > 50000 nM
Compound 3 was reported as a limit (the forecaster's own chance of this, stated with the estimate: 55%); middle value at least 1.2-fold (0.09 log units) from the limit.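

Compound 1 and compound 3 both stand at a limit in this assay and not at a number, so no step can be read between them: the limit of > 50000 nM in this assay, at which 2 of the 3 values shown sit.

The compounds shown leave open whether phenyl in place of 2-methoxyethyl on an amide-type nitrogen changes the read-out in this assay at all, and by how much.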